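Swapping Acetyl for Methyl on a Fused Aromatic Core

A few compounds are considered here, and "the series" means these few. Any claim that something is new, unique, unknown or untested is made for them only; others in the source may bear on it.

Measured so far:
Compound 1, `Cc1nc2cc3c(cc2n1-c1ccccc1)C1CNCC3C1`, gives < 5 nM in an assay on HEK293 cells for binding affinity to Neuronal acetylcholine receptor; alpha4/beta2 (Homo sapiens) (a higher number here means a weaker inhibitor, a lower number a stronger inhibitor), a value that is a limit of the assay rather than a number.
Compound 2, `CC(=O)c1ccc2c(c1)C1CNCC2C1`, gives 0.17 nM in this assay.

Going by the values given here, compound 2 thus holds the only actual number in this assay. For compound 1 the assay reports only a limit: the limit of < 5 nM in this assay, at which 1 of the 2 values shown sits. Compound 3, `Cc1ccc2c(c1)C1CNCC2C1`, has not yet been measured. It differs from compound 2 in a single place: methyl in place of acetyl on an aromatic carbon. Among the compounds with values here, no step between two measured compounds is available, so the size and direction of this change have to be judged from the structures alone. The acetyl that leaves carries a hydrogen-bond acceptor, while the methyl that enters carries none; the expected step of a 5.9-fold higher number from compound 2 to compound 3 (0.77 log units; beyond the scatter) is a moderate loss of affinity, somewhat beyond the usual scatter. Compound 3 is therefore expected to give about 1 nM in this assay, with a likely range from 0.2 nM to 5 nM.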

Compound 3, inhibition constant: 1.6 nM
Compound 3: the middle estimate sits 1.6-fold (0.20 log units) below what was measured; the measured number falls inside the stated range.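

Methyl in place of acetyl on this aromatic carbon gives a 9.4-fold higher number from compound 2 to compound 3 (0.97 log units; beyond the scatter) in this assay, the first change at this position that can be read as a step. The acetyl is therefore not required for a low number here: without it, compound 3 still gives 1.6 nM, although the step shows that the swap does cost affinity. Nothing shown here explains the size of this step.

The swap removes the carbonyl and shortens the group in one move, so the compounds shown cannot tell which of these differences matters. An ethyl group, which keeps the carbon count of acetyl without its oxygen, and a methoxy group, which places an oxygen directly on the ring, are among the groups that would help separate the two.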